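The source may report more compounds than this note shows. Statements on the series, on what has been measured and on what is new or still open speak of the compounds shown alone.

In a functional assay on A549 cells (Homo sapiens) for cytotoxicity, read by MTT assay, with a stated time of 24 h, tested at 80 uM (a lower number here means a stronger effect, a higher number a weaker effect of the compound at the concentration tested), compound 1 `CCCCOC(=O)CCC(=O)N1CCN(CCCOc2cc3c(Nc4ccc(F)c(Cl)c4)ncnc3cc2OC)CC1` gives 36.9%, and compound 2 `CCCCCCCCCCCCOC(=O)CCC(=O)N1CCN(CCCOc2cc3c(Nc4ccc(F)c(Cl)c4)ncnc3cc2OC)CC1` gives 2.3%, the lower of the two numbers in the series. Among the measured compounds shown here, the only measured step that bears on the next change is a number 34.6 percentage points lower from compound 1 to compound 2 (beyond the scatter). Compound 3 `CCCCCCCCCCCCCCCCCCCCOC(=O)CCC(=O)N1CCN(CCCOc2cc3c(Nc4ccc(F)c(Cl)c4)ncnc3cc2OC)CC1` differs from compound 2 by octyl in place of hydrogen on a saturated chain carbon, ten or more bonds along the chain from an oxygen next to a carbonyl group. That earlier step was large, yet compound 2 already stands so far down in this assay that little room for a further drop remains. A step no larger than the scatter is therefore expected, a number 1.7 percentage points higher from compound 2 to compound 3 (within the scatter). For compound 3 the expected value is 4%, with a range from 0% to 16%.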

Compound 3, a percentage reported as activity, at one concentration (the size of the read-out at that concentration, not a potency): 85.2%
Compound 3: the middle estimate sits 81.2 percentage points below what was measured; measured number outside the range, above it.
By their numbers in this assay, from the lowest: compound 2; then compound 1; then compound 3.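

In this assay the same octyl change, placed further out along the chain, runs the opposite way: a number 82.9 percentage points higher from compound 2 to compound 3 (beyond the scatter), against a number 34.6 percentage points lower from compound 1 to compound 2 (beyond the scatter). Across these compounds the number therefore does not fall steadily as the chain grows: compound 2 stands lowest, while compound 3 at 85.2% stands above compound 1 at 36.9%. No measured evidence bears on this reversal. Still open, as far as these compounds go, are where between compound 2 and compound 3 the turn lies, for chains of intermediate length, and how a carboxylic acid in place of the chain ester would read.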